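The source may hold more compounds than are shown below. What is called first, only, known or untested is meant among the compounds shown, and "the series" means these compounds.

Compound 1 (`O=C(Nc1cccc(-c2ccsc2)c1)C(Cl)Cl`) has only a limit in a functional assay on NCI-H460 cells (Homo sapiens) for cytotoxicity, read by MTT assay, with a stated time of 68 h (a lower number here means a stronger inhibitor, a higher number a weaker inhibitor), which is > 50000 nM and not an exact number. Compound 2 (`O=C(Nc1cccc(-c2ccccc2F)c1)C(Cl)Cl`), which carries a different ring on the shared core, gives 26800 nM in this assay. Compound 3 (`O=C(Nc1cccc(-c2ccoc2)c1)C(Cl)Cl`) has furan-3-yl in place of thiophen-3-yl on an aromatic carbon. For the measured compounds named here, no measured pair shows what this swap does, so no step beyond the usual scatter is expected in this assay. The expected step is an at least 1.2-fold lower number from compound 1 to compound 3 (0.09 log units; that floor lies within the scatter). The estimated value for compound 3 is 40000 nM, with an expected range of 15000 nM to 80000 nM.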

Compound 3, half-maximal inhibitory concentration: 37600 nM
Estimate against measurement, compound 3: 1.1-fold (0.03 log units) above, within the range that was stated.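

In this assay, furan-3-yl in place of thiophen-3-yl on this aromatic carbon gives an at least 1.3-fold lower number from compound 1 to compound 3 (0.12 log units; that floor lies within the scatter). Among the five-membered aromatic rings shown at this position, compound 3 supplies the only exact number, 37600 nM. The step remains a floor rather than a full size, because compound 1 has only a limit: the limit of > 50000 nM in this assay, at which 1 of the 3 values shown sits.

Still open, going by these compounds, is how a smaller or differently charged group at this position, such as an amine or a carboxylic acid, would read in this assay.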